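The compounds below may be only part of what the source reports. "The series", "measured", "known", "first", "only" and "open" are said of these compounds alone.

In a functional assay on DU-145 cells (Homo sapiens) for inhibition, read by trypan blue exclusion, with a stated time of 96 h (on this read-out lower numbers stand for stronger inhibition of growth and higher numbers for weaker inhibition of growth), compound 3 `O=C(/C(=C\c1ccc(Br)c([N+](=O)[O-])c1)Sc1ccc(Br)cc1)c1ccc(Br)cc1` gives 1000 nM and stands level with compound 2 `O=C(/C(=C\c1csc([N+](=O)[O-])c1)S(=O)(=O)c1ccc(Br)cc1)c1ccc(Br)cc1` at 1000 nM as the lowest pair of numbers in the set, while compound 1 `O=C(/C(=C\c1ccc(F)c([N+](=O)[O-])c1)S(=O)(=O)c1ccc(Br)cc1)c1ccc(Br)cc1` gives 25000 nM as the highest. Compound 4 `O=C(/C(=C\c1ccc(Br)c([N+](=O)[O-])c1)S(=O)(=O)c1ccc(Br)cc1)c1ccc(Br)cc1` carries (4-bromophenyl)sulfonyl in place of (4-bromophenyl)sulfanyl on a double-bonded chain carbon bound to a carbonyl carbon and a double-bonded chain carbon. Going by the values given here, no measured pair shows this exchange directly. Among the compounds with values here, the single measured step is a 25-fold lower number from compound 1 to compound 2 (1.40 log units; beyond the scatter) and it is large, but it lies at another place, and both of its compounds already hold the (4-bromophenyl)sulfonyl group. Within the data shown here, that step shows only that compounds with this group can read anywhere from compound 2 at 1000 nM to compound 1 at 25000 nM in this assay depending on the other aryl group. A moderate move towards a higher number is therefore expected, with wide uncertainty. The expected change is a 3.0-fold higher number from compound 3 to compound 4 (0.48 log units; beyond the scatter) (an estimate only). Compound 4 is estimated at 3000 nM with 600 nM to 15000 nM as its expected range.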

Compound 4, concentration for 50% growth inhibition: 10000 nM
The estimate for compound 4 lay 3.3-fold (0.52 log units) below the measured number; the range from low to high includes it.
By their numbers in this assay, from the lowest: compounds 2 and 3 (each within the scatter of the next); then compound 4; then compound 1.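

In this assay the exchange at this position now has a direct reading: (4-bromophenyl)sulfonyl in place of (4-bromophenyl)sulfanyl on a double-bonded chain carbon bound to a carbonyl carbon and a double-bonded chain carbon gives a 10-fold higher number from compound 3 to compound 4 (1.00 log units; beyond the scatter), a change beyond the scatter. With the sulfonyl group held fixed, 4-bromo-3-nitrophenyl in place of 5-nitrothiophen-3-yl gives a 10-fold higher number from compound 2 to compound 4 (1.00 log units; beyond the scatter), and bromo in place of fluoro on an aromatic carbon gives a 2.5-fold lower number from compound 1 to compound 4 (0.40 log units; beyond the scatter), so both of these exchanges also shift the reading beyond the scatter. No evidence at hand accounts for any of these steps.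

Going by these compounds, whether the sulfanyl and sulfonyl exchange reads the same way with the 5-nitrothiophen-3-yl group remains open. Also open, on these data alone, is how a sulfinyl group at this position, or an amine in place of the nitro group, would read.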